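This account rests on a few compounds, and the source may have more. Where it says the series, first, only, none or still open, it means among the compounds named here.

In an ADME assay on Vero 76 cells (Chlorocebus sabaeus) for cytotoxicity, read by microscopy (a lower number here means that less compound is tolerated, a higher number that more compound is tolerated), compound 1 `CC(C)C(Nc1nc(Cl)nc2c1ncn2[C@H]1[C@H](O)[C@H](O)[C@]2(CO)C[C@H]12)C(C)C` gives > 100000 nM, which is a limit. Compound 2 `NCCCNC(=O)[C@@]12C[C@@H]1[C@@H](n1cnc3c(NC(C4CC4)C4CC4)nc(Cl)nc31)[C@H](O)[C@@H]2O` gives > 50000 nM, also a limit. Compound 3 `CSc1nc(N[C@@H](C2CC2)C(C)(C)O)c2ccn([C@H]3[C@H](O)[C@H](O)[C@]4(CO)C[C@H]34)c2n1` gives > 100000 nM, again a limit. Among the compounds with values here, compound 1 thus has no numeric value, and neither do the other two, so no measured step exists to calibrate a change. Compound 4 `CC(C)(O)[C@@H](Nc1nc(Cl)nc2c1ncn2[C@H]1[C@H](O)[C@H](O)[C@]2(CO)C[C@H]12)C1CC1` has 1-cyclopropyl-2-hydroxy-2-methylpropyl in place of 1-isopropyl-2-methylpropyl on a nitrogen on an aromatic ring. With compound 1 at > 100000 nM, a limit, a result at or near that limit is expected. The expected step in this assay is a number no higher from compound 1 to compound 4 (the limit leaves the size open), with none beyond the scatter in either direction. For compound 4 the estimate is 100000 nM, with an expected range of 50000 nM to 200000 nM.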

Compound 4, half-maximal cytotoxic concentration: > 100000 nM
Compound 4 gave a limit, no number (the forecaster's own chance of this, stated with the estimate: 90%); the middle value sits exactly at the limit.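

In this assay no step can be read from compound 1 to compound 4, since both results are limits: the limit of > 100000 nM in this assay, at which 3 of the 4 values shown sit.

The compounds shown leave open whether 1-cyclopropyl-2-hydroxy-2-methylpropyl in place of 1-isopropyl-2-methylpropyl changes tolerated concentration at all.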